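This account rests on a few compounds, and the source may have more. Where it says the series, first, only, none or still open, it means among the compounds named here.

Working notes on the series. The shared core is kept throughout and the variation sits on a triple-bonded carbon; agonism is read in a functional assay on 1321-N1 cells for agonist activity at Free fatty acid receptor 1 (Homo sapiens), read by calcium flux, with a stated time of 0.4 s; a lower number here means that less compound is needed, a higher number that more compound is needed for the effect. Compound 1 `C/C(C#Cc1ccc(CCC(=O)O)c(F)c1)=C/CO` gives 427 nM in this assay. Compound 3 `CCCCCCCC#Cc1ccc(CCC(=O)O)cc1` gives 1450 nM in this assay. Compound 2 `C#Cc1ccc(CCC(=O)O)cc1`, bearing hydrogen on the triple-bonded carbon, returns > 100000 nM in this assay, a limit of the assay and not a number; it sits at the limit of > 100000 nM in this assay, at which 1 of the 3 values shown sits. Compound 4 `O=C(O)CCc1ccc(C#CC2CCCCC2)cc1` differs from compound 2 by cyclohexyl in place of hydrogen on a triple-bonded carbon. Going by the values given here, no step between measured compounds is available; still, compound 1 at 427 nM and compound 3 at 1450 nM carry substituents on the triple-bonded carbon where compound 2 carries hydrogen, so a move well beyond the scatter toward lower concentration is expected. The expected step is an at least 66-fold lower number from compound 2 to compound 4 (1.82 log units; beyond the scatter). Compound 4 is estimated at 1500 nM, between 400 nM and 6000 nM.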

Compound 4, half-maximal effective concentration: 513 nM
Estimate against measurement, compound 4: 2.9-fold (0.47 log units) above; the measured number falls inside the stated range.
By their numbers in this assay, from the lowest: compounds 1 and 4 (each within the scatter of the next); then compound 3. At a limit, above all of these: compound 2.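

Cyclohexyl in place of hydrogen on a triple-bonded carbon gives an at least 190-fold lower number from compound 2 to compound 4 (2.28 log units; beyond the scatter) in this assay, which shows that a six-membered non-aromatic carbon ring is accepted at this place, and not only the open chain of compound 3. Compound 2 stands at a limit of the assay and not a number, so the step gives only a bound: the limit of > 100000 nM in this assay, at which 1 of the 4 values shown sits.

Going by these compounds, whether cyclopropyl, phenyl or a chain ending in an amine would serve on this triple-bonded carbon stays open. Also open, on these data alone, is how cyclohexyl would read on the fluorinated core of compound 1.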